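The source may report more compounds than this note shows. Statements on the series, on what has been measured and on what is new or still open speak of the compounds shown alone.

Two sulfonamides built on the same bis(trifluoromethyl)phenyl core have been measured in a functional assay on BXPC-3 cells (Homo sapiens) for inhibition, read by MTT assay, with a stated time of 72 h; a higher number here means a weaker inhibitor of growth, a lower number a stronger inhibitor of growth. Compound 1, `O=S(=O)(NCCNCc1cccc2ccccc12)c1cc(C(F)(F)F)cc(C(F)(F)F)c1`, gives 23000 nM in this assay. Compound 2, `O=S(=O)(NCCCCNCc1ccc(Br)cc1)c1cc(C(F)(F)F)cc(C(F)(F)F)c1`, gives 1700 nM in this assay, which places it as the lower of the two numbers, with the gap to compound 1 falling beyond the usual scatter, so compound 2 stands as the stronger inhibitor of growth among the pair.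

The next step leads to compound 3, `CN(CCCNS(=O)(=O)c1cc(C(F)(F)F)cc(C(F)(F)F)c1)Cc1ccccc1`, which has not yet been measured in this assay. Relative to compound 2 the change is benzyl(methyl)amino in place of ((4-bromobenzyl)amino)methyl on a saturated chain carbon, three bonds along the chain from a sulfonamide nitrogen. Among the measured compounds shown here, no step between measured compounds that differ in only one place is available here, so the direction of this change cannot be read from a measured precedent, and the expectation rests on the values of compound 1 and compound 2 alone. Compound 3 is expected to move toward a higher number than compound 2, with an estimated step of a 4.7-fold higher number from compound 2 to compound 3 (0.67 log units; beyond the scatter) in this assay. For compound 3 the estimated value in this assay is 8000 nM, within a range from 2500 nM to 25000 nM.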

Compound 3, concentration for 50% growth inhibition: 39000 nM
Compound 3: middle estimate off by 4.9-fold (0.69 log units), on the low side; measured number above the stated range.
By their numbers in this assay, from the lowest: compound 2; then compounds 1 and 3 (each within the scatter of the next).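

In this assay, among the compounds shown here, placing benzyl(methyl)amino in place of ((4-bromobenzyl)amino)methyl on a saturated chain carbon, three bonds along the chain from a sulfonamide nitrogen, gives a 23-fold higher number from compound 2 to compound 3 (1.36 log units; beyond the scatter), the first directly readable step and a large one toward weaker inhibition of growth. The step shows that activity at this place is sensitive to this exchange, even though both groups keep one six-membered aromatic ring of carbon only and 1 hydrogen-bond acceptor, while the group that leaves carries a bromine and 1 hydrogen-bond donor and the group that enters carries neither. No measurement is available that accounts for the size of this step.

For the compounds shown here, the single step changes these features together, so the share of the bromine and that of the hydrogen-bond donor cannot be told apart. A ((benzyl)amino)methyl group or a (4-bromobenzyl)(methyl)amino group at this place would separate the two, and a 4-chlorobenzyl group would show whether another halogen could stand in for the bromine.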